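Removing one methyl from compound 2: expected cytotoxicity

The source may report more compounds than this note shows. Statements on the series, on what has been measured and on what is new or still open speak of the compounds shown alone.

Compound 1 `Cc1nnc(SCc2cc(=O)c3ccccc3o2)s1`: in a functional assay on LM7 cells (Homo sapiens) for cytotoxicity, read by MTT assay, with a stated time of 72 h (on this read-out lower numbers stand for stronger inhibition and higher numbers for weaker inhibition), compound 1 gives > 25000 nM, a limit of the assay and not a number.
Compound 2 `Cc1ccc2oc(CSc3nc4nc(C)cc(C)n4n3)cc(=O)c2c1`: in this assay compound 2 gives > 25000 nM, which is likewise a limit and not a number.

Among the measured compounds shown here, compound 2 stands at the limit of > 25000 nM in this assay, at which 2 of the 2 values shown sit, so the two values shown together give no number for compound 2 and no step between the measured compounds that could be sized. Compound 3 `Cc1cc(C)n2nc(SCc3cc(=O)c4ccccc4o3)nc2n1` differs from compound 2 by hydrogen in place of methyl on an aromatic carbon, a change at the carbon-only six-membered aromatic ring of the fused system. With both measured values sitting at the limit, the data carry nothing to suggest that this change moves the read-out either way, and the expected step in this assay is none beyond the scatter; the estimate places it at a step that the limit leaves unreadable from compound 2 to compound 3. Compound 3 is therefore expected to give about 30000 nM in this assay, with a range from 10000 nM to 100000 nM, and the most likely outcome is that the assay again reports only a limit rather than a number.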

Compound 3, half-maximal inhibitory concentration: > 25000 nM
Compound 3: no number, only a limit (the forecaster's own chance of this, stated with the estimate: 80%); the middle value is on the limit's open side.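

No step can be read from compound 2 to compound 3, because each of the two gives only a limit of the assay and not a number: the limit of > 25000 nM in this assay, at which 3 of the 3 values shown sit.

The compounds shown leave open whether hydrogen in place of methyl on that aromatic carbon changes the read-out in this assay at all, and what number any of them would give.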